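From a Chlorinated Aryl Group to a Hydroxylated One

The source may report more compounds than this note shows. Statements on the series, on what has been measured and on what is new or still open speak of the compounds shown alone.

Going by the values given here, in a functional assay on HepG2 cells (Homo sapiens) for inhibition, read by MTT assay, with a stated time of 72 h (on this read-out higher numbers stand for weaker inhibition and lower numbers for stronger inhibition), compound 2, `C#CCSc1nc(Nc2cccc(Cl)c2)c2ccncc2n1`, gives 1090 nM, the only numerical value among the compounds measured so far. Compound 1, `C#CCSc1nc(NCCC#N)c2ccncc2n1`, reaches only a limit of the assay, > 80000 nM. Among the compounds with values here, the single measured step, an at least 73-fold lower number from compound 1 to compound 2 (1.86 log units; beyond the scatter), rests on the limit of > 80000 nM in this assay, at which 1 of the 2 values shown sits, and shows that an aryl ring on that nitrogen in place of a chain gives a far lower number. Compound 3, `C#CCSc1nc(Nc2ccc(O)cc2)c2ccncc2n1`, keeps the aryl ring and changes only its substituent: 4-hydroxyphenyl in place of 3-chlorophenyl on a nitrogen on an aromatic ring. Within the data shown here, no measured step compares one substituted phenyl ring with another, so the step from compound 1 to compound 2 speaks about the ring itself rather than about what sits on it. The change from compound 2 to compound 3 is therefore expected to be modest, possibly within the scatter, as a 2.3-fold higher number from compound 2 to compound 3 (0.36 log units; beyond the scatter). Compound 3 is estimated at 2500 nM, with a range from 700 nM to 12000 nM.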

Compound 3, half-maximal inhibitory concentration: > 80000 nM
Compound 3 ended at the assay's limit (the forecaster's own chance of this, stated with the estimate: 10%); middle value at least 32-fold (1.50 log units) away from the limit.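

The change from 3-chlorophenyl to 4-hydroxyphenyl gives an at least 73-fold higher number from compound 2 to compound 3 (1.86 log units; beyond the scatter) in this assay, so at this nitrogen the result depends on what the aryl ring carries, not merely on the ring being there. Compound 3 keeps an aryl ring and gives > 80000 nM, which is a limit of the assay and not a number. Compound 1 and compound 3 both end at a limit, so the step between them cannot be read, and the size of the step above rests on that same limit: the limit of > 80000 nM in this assay, at which 2 of the 3 values shown sit.

The two rings differ both in the group they carry and in where it sits, so the compounds shown cannot tell which of these matters. A 4-chlorophenyl or 3-hydroxyphenyl ring would separate the two, and a phenyl ring carrying an amine or a methoxy group would show how far other groups are accepted here.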